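Nitro for bromo on the pendant aryl: series notes

The compounds below may be only part of what the source reports. "The series", "measured", "known", "first", "only" and "open" are said of these compounds alone.

Compound 1 `Nc1scc(-c2ccc(Br)cc2)c1C(=O)c1ccccc1` in a functional assay on CHO cells for agonist activity at adenosine receptor A1 (Homo sapiens), read by fluorescence and ERK phosphorylation, with stated times of 30 min and 1.5 h, tested at 10 uM (a lower number here means a weaker effect, a higher number a stronger effect of the compound at the concentration tested), gives 49%. Compound 2 `Nc1scc(-c2ccc([N+](=O)[O-])cc2)c1C(=O)c1ccccc1` gives 47% in this assay. The step of a number 2 percentage points lower from compound 1 to compound 2 (within the scatter) accompanies the change (nitro in place of bromo on an aromatic carbon). Compound 3 `Nc1scc(-c2cccc(Br)c2)c1C(=O)c1ccc(Cl)cc1` gives 69% in this assay; its values against compound 1 and compound 2 show it as the highest of the three measured, both gaps lying beyond the scatter. The difference between the core of compound 1 and the core of compound 3 is not broken down here.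

Compound 4 `Nc1scc(-c2cccc([N+](=O)[O-])c2)c1C(=O)c1ccc(Cl)cc1` remains to be measured in this assay. It differs from compound 3 by nitro in place of bromo on an aromatic carbon. This is the same kind of change as that from compound 1 to compound 2, not the same: there the place was para to a large group, here it is meta to a large group. The expected step, a number 3 percentage points lower from compound 3 to compound 4 (within the scatter), rests on the observation that a number 2 percentage points lower from compound 1 to compound 2 (within the scatter) lay within the scatter; the different place adds some uncertainty. Compound 4 is therefore expected to give about 66% in this assay, estimated between 50% and 80%.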

Compound 4, a percentage reported as activity, at one concentration (the size of the read-out at that concentration, not a potency): 42%
For compound 4 the middle estimate is 24 percentage points above the measured one; the whole stated range lies above it.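

Nitro in place of bromo does not carry over as a constant step from one core to the other in this assay: the same change on two cores in this assay, a number 2 percentage points lower (within the scatter) from compound 1 to compound 2 and a number 27 percentage points lower (beyond the scatter) from compound 3 to compound 4, 25 percentage points apart, beyond the scatter of two such steps

The new step, a number 27 percentage points lower from compound 3 to compound 4 (beyond the scatter), shows that a swap with no step beyond the scatter on one core can give a clear loss of the read-out on another, so the step seen on the core of compound 1 is no safe guide for the core of compound 3. What this does not show is the source of the gap: the two pairs differ both in the place of the change and in the rest of the core, and two pairs cannot separate these or give a rule for any further core.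

As far as these compounds go, it remains open whether the two places would give different steps on a single core. Also open, from the compounds shown here alone, is whether an amine, a carboxylic acid or a nitrile at the same place would track bromo or nitro on either core.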